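This account rests on a few compounds, and the source may have more. Where it says the series, first, only, none or still open, it means among the compounds named here.

Working notes on a three-arm pyridine series tested in an assay on isolated protein for inhibition of DNA topoisomerase 1 (Homo sapiens), with a stated time of 30 min, tested at 100 uM; a lower number here means a weaker effect, a higher number a stronger effect of the compound at the concentration tested.

Compound 1 `Oc1ccccc1-c1cc(-c2ccco2)cc(-c2ccccc2O)n1` gives 89.1% in this assay. Compound 2 `Oc1cccc(-c2cc(-c3ccco3)cc(-c3ccccc3O)n2)c1` gives 90.1%. The two differ by 3-hydroxyphenyl in place of 2-hydroxyphenyl on an aromatic carbon, and the step is a number 1 percentage points higher from compound 1 to compound 2 (within the scatter): the two numbers sit within the scatter of each other.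

Compound 3 `Oc1ccccc1-c1cc(-c2ccccn2)cc(-c2ccccc2O)n1` gives 0.8%, the lowest of the three numbers. For the measured compounds named here, it differs from compound 1 by pyridin-2-yl in place of furan-2-yl on an aromatic carbon, and the step is a number 88.3 percentage points lower from compound 1 to compound 3 (beyond the scatter); this is the one large change seen so far, and compound 3 stands beyond the scatter from both compound 1 and compound 2.

Compound 4 `Oc1cccc(-c2cc(-c3ccccn3)cc(-c3ccccc3O)n2)c1` has not yet been measured. It differs from compound 3 by 3-hydroxyphenyl in place of 2-hydroxyphenyl on an aromatic carbon. Going by the values given here, this is the same kind of change as the one from compound 1 to compound 2, but not the same: in compound 1 the place is "meta to a furan-2-yl group", whereas in compound 3 it is "meta to a pyridin-2-yl group", the two cores differing by pyridin-2-yl in place of furan-2-yl on an aromatic carbon.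

The step from compound 3 to compound 4 is expected to be small, a number 3.2 percentage points higher from compound 3 to compound 4 (within the scatter), because the same kind of change gave a number 1 percentage points higher from compound 1 to compound 2 (within the scatter) on the other core. Since compound 3 starts near zero, little room exists for a fall. Compound 4 is therefore estimated to give 4%, with a likely range from 0% to 18%.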

Compound 4, a percentage reported as inhibition, at one concentration (the size of the read-out at that concentration, not a potency): 35.4%
Compound 4: the middle estimate sits 31.4 percentage points below what was measured; measured number outside the range, above it.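

In this assay, 3-hydroxyphenyl in place of 2-hydroxyphenyl gives a number 34.6 percentage points higher from compound 3 to compound 4 (beyond the scatter), so the near-silent result of this change on the furan-2-yl core does not carry over to the pyridin-2-yl core: the same change on two cores in this assay, a number 1 percentage points higher (within the scatter) from compound 1 to compound 2 and a number 34.6 percentage points higher (beyond the scatter) from compound 3 to compound 4, 33.6 percentage points apart, beyond the scatter of two such steps. Seen from the other direction, pyridin-2-yl in place of furan-2-yl gives a number 54.7 percentage points lower from compound 2 to compound 4 (beyond the scatter), so this change lowers the number on both hydroxyphenyl patterns, but the size of the fall depends on which pattern is present: the same change on two cores in this assay, a number 88.3 percentage points lower (beyond the scatter) from compound 1 to compound 3 and a number 54.7 percentage points lower (beyond the scatter) from compound 2 to compound 4, 33.6 percentage points apart, beyond the scatter of two such steps. These two pairs show that the two changes do not act independently in this series, but they do not show why or how either change would behave on a third core, and each number tells only of a stronger or weaker effect at the single concentration tested.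

On these data alone, it remains open whether a thiophen-2-yl or plain phenyl group in the place of the furan-2-yl or pyridin-2-yl group would follow the furan-2-yl or the pyridin-2-yl pattern. As far as these compounds go, it also remains open whether the hydroxyl of the 3-hydroxyphenyl group could be replaced by a methoxy group or an amine while keeping the higher number seen for compound 4 over compound 3.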